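From morpholin-4-yl to methylamino on a carbonyl carbon

The compounds below may be only part of what the source reports. "The series", "measured", "known", "first", "only" and "open" are said of these compounds alone.

Measured so far in a functional assay on MCF7 cells (Homo sapiens) for inhibition, read by sulforhodamine B assay, with a stated time of 72 h; on this read-out higher numbers stand for weaker inhibition of growth and lower numbers for stronger inhibition of growth:
- Compound 1 `NNC(=O)CCc1ccncc1-c1ccc2ccccc2c1` gives > 10000 nM (a limit)
- Compound 2 `O=C(O)/C=C/c1ccncc1-c1ccc2ccccc2c1` gives > 10000 nM (a limit)
- Compound 3 `O=C(CCc1ccncc1-c1ccc2ccccc2c1)N1CCOCC1` gives > 10000 nM (a limit)

Compound 3 stands only at a limit, > 10000 nM. Among the measured compounds shown here, the series so far shows (the limit of > 10000 nM in this assay, at which 3 of the 3 values shown sit), so no number places compound 3 relative to the others. Compound 4 `CNC(=O)CCc1ccncc1-c1ccc2ccccc2c1` differs from it in one group: methylamino in place of morpholin-4-yl on a carbonyl carbon. In words, methylamino replaces morpholin-4-yl on a carbonyl carbon.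

The closest measured change, at that same carbonyl carbon, is a step that the two limits leave unreadable from compound 1 to compound 3. The other measured change, at a different place, is a step that the two limits leave unreadable from compound 1 to compound 2. Neither gives a size to carry forward. Neither of the groups tried on that carbonyl carbon brought a value inside the limit, so no readable gain in this assay is expected, and the estimated step is a step that the limit leaves unreadable from compound 3 to compound 4. The estimated value for compound 4 is 14000 nM, with an expected range from 5000 nM to 40000 nM.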

Compound 4, concentration for 50% growth inhibition: > 10000 nM
Compound 4: only a limit was reported (the forecaster's own chance of this, stated with the estimate: 80%); the middle value lies beyond the limit too.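

In this assay compound 4 gives > 10000 nM, which is a limit, so its steps from compound 1, compound 2 and compound 3 cannot be read. The compounds shown leave open how strongly any of them inhibits growth, and which change would bring a value inside the limit: the limit of > 10000 nM in this assay, at which 4 of the 4 values shown sit.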